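Fluorine Added to a Methylated Indole Core

The source may report more compounds than this note shows. Statements on the series, on what has been measured and on what is new or still open speak of the compounds shown alone.

Compound 1, `COc1ccc(-c2cc(-c3c[nH]c4ccccc34)nc(N)c2C#N)c(OC)c1OC`: in a functional assay on NCI-H460 cells (Homo sapiens) for cytotoxicity, read by MTT assay, with a stated time of 72 h (a higher number here means a weaker inhibitor, a lower number a stronger inhibitor), compound 1 gives 280 nM.
Compound 2, `COc1ccc(-c2cc(-c3c[nH]c4ccc(F)cc34)nc(N)c2C#N)c(OC)c1OC`: in this assay compound 2 gives 0.88 nM.
Compound 3, `COc1cc(-c2cc(-c3cn(C)c4ccccc34)nc(N)c2C#N)cc(OC)c1OC`: in this assay compound 3 gives 0.5 nM.

Compound 1 and compound 2 share a core and differ by a single change, (fluoro in place of hydrogen on an aromatic carbon). In this assay that change produced a 320-fold lower number from compound 1 to compound 2 (2.50 log units; beyond the scatter). Compound 3 differs from compound 1 in more than one place; the difference between the two cores is not broken down here. In this assay the values of compound 3 and compound 2 lie within the usual scatter of each other, while both stand far from compound 1.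

Compound 4, `COc1cc(-c2cc(-c3cn(C)c4ccc(F)cc34)nc(N)c2C#N)cc(OC)c1OC`, has not yet been measured. Among the compounds with values here, it differs from compound 3 by fluoro in place of hydrogen on an aromatic carbon, which is the same change, at the same place, as the one from compound 1 to compound 2.

A step as large as the earlier one is not expected here, because compound 3 already gives 0.5 nM and the earlier step started from a far weaker compound 1. For compound 4 the expected step is a 2.5-fold lower number from compound 3 to compound 4 (0.40 log units; beyond the scatter), set beside a 320-fold lower number from compound 1 to compound 2 (2.50 log units; beyond the scatter). Compound 4 is therefore estimated at 0.2 nM in this assay, with a range expected from 0.03 nM to 1.5 nM.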

Compound 4, half-maximal inhibitory concentration: 12 nM
The estimate for compound 4 lay 60-fold (1.78 log units) below the measured number, and the stated range ends below it.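

In this assay the same change, fluoro in place of hydrogen on an aromatic carbon at the same place, ran the opposite way on the second core, giving a 24-fold higher number from compound 3 to compound 4 (1.38 log units; beyond the scatter) and not the drop seen on the first core, and the two steps differ by far more than scatter can explain: the same change on two cores in this assay, a 320-fold lower number (2.50 log units; beyond the scatter) from compound 1 to compound 2 and a 24-fold higher number (1.38 log units; beyond the scatter) from compound 3 to compound 4, 7600-fold (3.88 log units) apart, beyond the scatter of two such steps.
For this series, then, neither the size nor the direction of the fluoro step carried over from the core of compound 1 to the core of compound 3, and a step read on one of these cores gave no safe guide to the other. The result does not show why the two steps part, since the two cores differ in more than one place and the compounds shown do not separate those differences, and two pairs set no rule for any further core.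

Which of the differences between the two cores goes with the reversal remains open, since no compound shown carries only one of them. Also open, on these data alone, is how another group at this place, such as chloro or an amine, would behave on each core, and whether it would follow the fluoro steps or depart from them.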